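Pyridin-4-yl in place of 3-(methylsulfonyl)phenyl on the shared core

The compounds below may be only part of what the source reports. "The series", "measured", "known", "first", "only" and "open" are said of these compounds alone.

Compound 1 `C[C@H](Nc1ncnc2[nH]cnc12)c1nn(-c2cccnc2)c2cc(F)ccc12`: > 40000 nM (a limit)
Compound 2 `C[C@H](Nc1ncnc2[nH]cnc12)c1nn(-c2cccc(S(C)(=O)=O)c2)c2cc(F)ccc12`: 20000 nM

Going by the values given here, in a functional assay on Bel-7402 cells (Homo sapiens) for inhibition, read by sulforhodamine B assay, with a stated time of 72 h (a lower number here means a stronger inhibitor, a higher number a weaker inhibitor), compound 2 gives 20000 nM, the only actual number so far. Compound 3 `C[C@H](Nc1ncnc2[nH]cnc12)c1nn(-c2ccncc2)c2cc(F)ccc12` makes the change (pyridin-4-yl in place of 3-(methylsulfonyl)phenyl on an aromatic nitrogen). Among the compounds with values here, one measured step bears on this: an at least 2.0-fold lower number from compound 1 to compound 2 (0.30 log units; that floor lies within the scatter). It swapped pyridin-3-yl for the same 3-(methylsulfonyl)phenyl group that compound 3 gives up, so a small move back towards a higher number is expected in this assay. The expected step, probably within the scatter, is a 1.8-fold higher number from compound 2 to compound 3 (0.24 log units; within the scatter). Compound 3 is estimated at 35000 nM, with an expected range of 15000 nM to 80000 nM.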

Compound 3, half-maximal inhibitory concentration: > 40000 nM
Compound 3: only a limit was reported; the forecaster's own chance of this, stated with the estimate: 55%; at least 1.1-fold (0.05 log units) between middle value and limit.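

In this assay, pyridin-4-yl on the aromatic nitrogen gives a second limit, with compound 3 at > 40000 nM. Leaving 3-(methylsulfonyl)phenyl for this group gives an at least 2.0-fold higher number from compound 2 to compound 3 (0.30 log units; that floor lies within the scatter). The step between pyridin-3-yl and pyridin-4-yl cannot be read, and the two pyridine compounds share one ceiling: the limit of > 40000 nM in this assay, at which 2 of the 3 values shown sit.

As far as these compounds go, whether a plain phenyl, or a phenyl bearing an amine or a carboxylic acid, would give a lower number than compound 2 stays open. So does the true size of any difference between compound 1 and compound 3.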